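This account rests on a few compounds, and the source may have more. Where it says the series, first, only, none or still open, it means among the compounds named here.

Of the compounds shown here, three have been measured in an ADME assay on microsomes from liver (Rattus norvegicus) for metabolic stability; on this read-out lower numbers stand for a shorter-lived compound and higher numbers for a longer-lived compound. Compound 1 (`CC(C)C(c1ccc(-c2ccc3cccc(F)c3c2)[nH]c1=O)C1NC(=O)NC1=O`) gives 0.145 h, compound 2 (`CCC(/C=C1\OC(=O)NC1=O)(CC)c1ccc(-c2ccc3cccc(C(C)C)c3c2)[nH]c1=O`) gives 1.88 h and compound 3 (`O=C1NC(=O)/C(=C/C(c2ccc(-c3ccc4cccc(F)c4c3)[nH]c2=O)C2CCCCC2)O1`) gives 2.39 h. Compound 3 thus stands within the scatter of compound 2, while compound 1 lies lower, well beyond the scatter from compound 3. Compound 4 (`O=C1NC(=O)/C(=C/C(c2ccc(-c3ccc4cccc(F)c4c3)[nH]c2=O)C2CCCC2)O1`) has not yet been measured. It differs from compound 3 in a single place, with cyclopentyl in place of cyclohexyl on a saturated chain carbon bound to an aromatic carbon and a double-bonded chain carbon. For the measured compounds named here, no two measured compounds differ in only one place, so the data hold no direct precedent for this exchange. Compound 1 differs from compound 3 in more than one place, and its low value says nothing specific about the ring exchange. The expectation therefore starts from compound 3 at 2.39 h, and no change beyond the scatter is foreseen in this assay. The estimated result is a 1.2-fold lower number from compound 3 to compound 4 (0.08 log units; within the scatter), a small step whose direction the data cannot settle. Compound 4 is expected at 2 h, with an estimated range from 0.9 h to 4.4 h.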

Compound 4, half-life: > 3 h
Compound 4 was reported as a limit; the forecaster's own chance of this, stated with the estimate: 5%; middle value at least 1.5-fold (0.17 log units) from the limit.
By their numbers in this assay, from the lowest: compound 1; then compounds 2 and 3 (each within the scatter of the next). At a limit, above all of these: compound 4.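

In this assay, compound 4 is reported as a limit, > 3 h, and not as a number. This gives the set its first comparison of compounds that differ in one place: cyclopentyl in place of cyclohexyl on a saturated chain carbon bound to an aromatic carbon and a double-bonded chain carbon gives an at least 1.2-fold higher number from compound 3 to compound 4 (0.09 log units; that floor lies within the scatter), so at this position the five-membered ring does not bring the drop that a shorter-lived compound would show, and the half-life stays at least level with that of the six-membered ring. On these data alone, the size of the step remains unknown, and the reading ends at the limit of the assay: the limit of > 3 h in this assay, at which 1 of the 4 values shown sits.

The compounds shown leave open how a still smaller ring such as cyclobutyl, or a ring carrying an oxygen atom such as tetrahydropyranyl, would fare at this place on the same core. They also leave open whether an exact value for compound 4 would set it beyond the scatter from compound 3, and compounds 1 and 2 differ from these two in more than one place, so they cannot settle either question.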